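From Butyl to Propyl, Starting at a Limit

A few compounds are considered here, and "the series" means these few. Any claim that something is new, unique, unknown or untested is made for them only; others in the source may bear on it.

Measured values in a functional assay on the whole organism for inhibition, with Rattus norvegicus as the target (on this read-out lower numbers stand for an effect already at smaller amounts and higher numbers for an effect only at larger amounts of compound), follow.
- Compound 1 `CCCc1nc(SC)c(C(=O)C[S+]([O-])c2ccc(C)cc2)n1Cc1ccc(-c2ccccc2S(=O)(=O)NC(=O)NCc2ccccc2)cc1` gives (1.5 mg/kg; 1.5 mg/kg (2 entries)).
- Compound 2 `CCCCc1nc(SC)c(C(=O)CS(=O)(=O)c2ccccc2)n1Cc1ccc(-c2ccccc2S(=O)(=O)NC(=O)NCc2ccccc2)cc1` gives (> 3 mg/kg), which is a limit.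
- Compound 3 `CCCCc1nc(SC)c(C(=O)CS(=O)(=O)c2ccc(F)cc2)n1Cc1ccc(-c2ccccc2S(=O)(=O)NC(=O)NCc2ccccc2)cc1` gives (> 3 mg/kg), which is a limit.

Compound 2 has no number, only a limit (the limit of > 3 mg/kg in this assay, at which 2 of the 3 values shown sit). Compound 4 `CCCc1nc(SC)c(C(=O)CS(=O)(=O)c2ccccc2)n1Cc1ccc(-c2ccccc2S(=O)(=O)NC(=O)NCc2ccccc2)cc1` differs from it as butyl to propyl, with hydrogen in place of methyl on a saturated chain carbon, three bonds along the chain from an aromatic carbon. Within the data shown here, the only measured step is (a step that the two limits leave unreadable from compound 2 to compound 3), fluoro in place of hydrogen on an aromatic carbon, and it offers no size to carry over. No step beyond the scatter is therefore expected in this assay in either direction, and the result may again be a limit. The expected step is (a number no higher from compound 2 to compound 4 (the limit leaves the size open)). The estimated value for compound 4 is (3 mg/kg), with an expected range from (1.2 mg/kg) to (7 mg/kg).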

Compound 4, dose for 50% inhibition: > 3 mg/kg
Compound 4 gave a limit, no number (the forecaster's own chance of this, stated with the estimate: 50%); the middle value lies on the limit itself.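

Compound 2 and compound 4 each give only a limit in this assay, so no step can be read between them: the limit of > 3 mg/kg in this assay, at which 3 of the 4 values shown sit.

The compounds shown leave open whether butyl and propyl differ at all in this assay.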